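The source may hold more compounds than are shown below. What is called first, only, known or untested is meant among the compounds shown, and "the series" means these compounds.

Compound 1 `O=C(NCCCCN1CCN(c2ccccc2)CC1)c1ccc(-c2ccsc2)cc1` stands at the lower of the two numbers recorded so far in an ADME assay on microsomes from liver (Rattus norvegicus) for metabolic stability, read by LC-MS, using NADPH (on this read-out higher numbers stand for a longer-lived compound and lower numbers for a shorter-lived compound), where compound 1 gives 0.41 h. Among the measured compounds shown here, its only measured neighbour, compound 2 `O=C(NCCCCN1CCN(c2ccc(Cl)cc2)CC1)c1ccc(-c2ccsc2)cc1`, gives 0.837 h in this assay, and the single step between them, a 2.0-fold higher number from compound 1 to compound 2 (0.31 log units; beyond the scatter), came from a chloro in place of hydrogen on an aromatic carbon. Compound 3 `Cc1ccc(N2CCN(CCCCNC(=O)c3ccc(-c4ccsc4)cc3)CC2)cc1` differs from compound 1 at that same place: methyl in place of hydrogen on an aromatic carbon. For the measured compounds named here, no measured step carries a methyl, so the chloro step bears on it only loosely, and an expectation of little change or a modest rise follows, as a 1.2-fold higher number from compound 1 to compound 3 (0.09 log units; within the scatter). The estimate for compound 3 is therefore 0.5 h, within 0.25 h to 1 h.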

Compound 3, half-life: 0.125 h
Compound 3: middle estimate off by 4.0-fold (0.60 log units), on the high side, and the stated range ends above it.
By their numbers in this assay, from the lowest: compound 3; then compound 1; then compound 2.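

In this assay the place para to a large group moves both ways, with a 3.3-fold lower number from compound 1 to compound 3 (0.52 log units; beyond the scatter) for methyl against a 2.0-fold higher number from compound 1 to compound 2 (0.31 log units; beyond the scatter) for chloro. Between chloro and methyl at this one place the gap is a 6.7-fold lower number from compound 2 to compound 3 (0.83 log units; beyond the scatter) and so the direction depends on which group enters, not on substitution as such. The compounds shown leave open how fluoro or methoxy would read at this place, and whether methyl would give the same step on a longer chain. Nothing at hand gives a reason for the opposite directions.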